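Tert-Butoxy for Methyl on the Carbonyl Carbon of Compound 1

The source may report more compounds than this note shows. Statements on the series, on what has been measured and on what is new or still open speak of the compounds shown alone.

Compound 1, `CC(=O)NN=C1C(Cl)=C(Cl)C(Cl)=C1Cl`, gives 1000 nM in a functional assay on RPMI-8226 cells (Homo sapiens) for cytotoxicity, read by MTT assay, with a stated time of 48 h; a higher number here means a weaker inhibitor, a lower number a stronger inhibitor.
Compound 2, `Fc1ccccc1NN=C1C(Cl)=C(Cl)C(Cl)=C1Cl`, reaches only a limit of this assay, > 3000 nM.
Compound 3, `CN(C)N=C1C(Cl)=C(Cl)C(Cl)=C1Cl`, likewise reaches only a limit, >= 1300 nM.

Among the measured compounds shown here, compound 1 is thus the one compound of the three with a number rather than a limit; the other two sit at the limit of > 3000 nM in this assay, at which 1 of the 3 values shown sits, and (the limit of >= 1300 nM in this assay, at which 1 of the 3 values shown sits). For the measured compounds named here, the only measured step with a single change, an at least 1.3-fold higher number from compound 1 to compound 3 (0.11 log units; that floor lies within the scatter), comes from putting dimethylamino in place of acetamido on a double-bonded nitrogen, and its floor lies within the scatter.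

Compound 4, `CC(C)(C)OC(=O)NN=C1C(Cl)=C(Cl)C(Cl)=C1Cl`, is not yet measured in this assay. It differs from compound 1 by tert-butoxy in place of methyl on a carbonyl carbon, a change at the carbonyl carbon whose other neighbour is the amide-type nitrogen. Going by the values given here, no measured step alters this carbonyl carbon, so the step to compound 3 bears on it only loosely, by showing that a change at this end of compound 1 moved the number little, if at all. With no evidence for a shift beyond the scatter, compound 4 is expected to stay close to compound 1, a step of a 1.2-fold higher number from compound 1 to compound 4 (0.08 log units; within the scatter), and its estimated value in this assay is 1200 nM, between 500 nM and 3000 nM.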

Compound 4, half-maximal inhibitory concentration: 100 nM
Compound 4: middle estimate off by 12-fold (1.08 log units), on the high side; the whole stated range lies above it.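

Tert-butoxy in place of methyl on a carbonyl carbon gives a 10-fold lower number from compound 1 to compound 4 (1.00 log units; beyond the scatter) in this assay and so shows that this carbonyl carbon, whose other neighbour is the amide-type nitrogen, is a place where one change can move the number well beyond the scatter. Among the compounds shown here, the only earlier step with a single change, an at least 1.3-fold higher number from compound 1 to compound 3 (0.11 log units; that floor lies within the scatter), had a floor within the scatter and replaced the whole acetamido group, so it left the effect of changing this carbon alone unseen. The new step also shows that the methyl of compound 1 can give way to a group with more heavy atoms without any loss in this assay, though no measurement shown explains why the number falls.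

Tert-butoxy brings an oxygen and extra carbons in one change, so the compounds shown leave open which of the two goes with the step; a methoxy group and a plain tert-butyl group on the same carbonyl carbon would begin to separate them. Also open, on these data alone, is how a longer chain such as n-butoxy, or an amine such as piperidine, would read at this carbon.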